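This account rests on a few compounds, and the source may have more. Where it says the series, first, only, none or still open, it means among the compounds named here.

Three compounds share one core and differ in the ester and in the aryl group on a saturated ring carbon. Compound 1 `CC1=C(C(=O)OC2CCCCC2)C(c2cccc(C(F)(F)F)c2)C2=C(CC(C)(C)CC2=O)N1` carries a cyclohexyl ester and a phenyl bearing a trifluoromethyl group; in an assay on HEK293 cells for inhibition of neurogenic locus notch homolog protein 1 (Homo sapiens), read by a luciferase reporter and resazurin assay, with a stated time of 16 h (on this read-out higher numbers stand for weaker inhibition and lower numbers for stronger inhibition), compound 1 gives 14700 nM. Compound 2 `CC1=C(C(=O)OCC2CCN(C(=O)OC(C)(C)C)CC2)C(c2cccc(C#N)c2)C2=C(CC(C)(C)CC2=O)N1` carries an ester built on a protected piperidine together with 3-cyanophenyl, and in this assay compound 2 gives 220 nM. Compound 3 `CC1=C(C(=O)OCC2CCN(C(=O)OC(C)(C)C)CC2)C(c2ccc3c(c2)OCCO3)C2=C(CC(C)(C)CC2=O)N1` keeps that ester and bears 2,3-dihydro-1,4-benzodioxin-6-yl; in this assay compound 3 gives 1520 nM, the second highest of the three numbers, nearer to compound 2 than to compound 1. Among the compounds with values here, the only measured aryl swap, a 6.9-fold higher number from compound 2 to compound 3 (0.84 log units; beyond the scatter), is modest yet beyond the scatter. Compound 4 `CC1=C(C(=O)OCC2CCN(C(=O)OC(C)(C)C)CC2)C(c2ccc3ccccc3n2)C2=C(CC(C)(C)CC2=O)N1` follows with quinolin-2-yl in place of 2,3-dihydro-1,4-benzodioxin-6-yl on a saturated ring carbon. Within the data shown here, no measured pair contains quinolin-2-yl, so the direction is open, and that earlier swap only sets the likely size. Compound 4 is therefore expected to come out near 900 nM, within a range from 200 nM to 4000 nM. Among the measured compounds shown here, the implied step a 1.7-fold lower number from compound 3 to compound 4 (0.23 log units; within the scatter) is estimated to stay within the size of the one aryl swap seen.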

Compound 4, half-maximal inhibitory concentration: 330 nM
Estimate against measurement, compound 4: 2.7-fold (0.44 log units) above; the range from low to high includes it.
By their numbers in this assay, from the lowest: compounds 2 and 4 (each within the scatter of the next); then compound 3; then compound 1.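

At this saturated ring carbon, the aryl group can change the number even when the heavy-atom count stays the same: the swap of 2,3-dihydro-1,4-benzodioxin-6-yl for quinolin-2-yl gives a 4.6-fold lower number from compound 3 to compound 4 (0.66 log units; beyond the scatter). The earlier compounds shown here showed only a single-ring phenyl group with a substituent giving a low number, yet quinolin-2-yl, with an aromatic ring that holds a nitrogen, does as well, with a 1.5-fold higher number from compound 2 to compound 4 (0.18 log units; within the scatter), so this assay does not separate it from 3-cyanophenyl. Nothing available here explains why the number moves with this swap.

Going by these compounds, whether the ring nitrogen of quinolin-2-yl matters remains open, and naphthalen-2-yl, with carbon in its place, would test that directly. The ester is also unresolved, including how a free piperidine amine, without the tert-butyl carbamate, would compare.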